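Cyclohexyl for Neopentyl on the Core of Compound 1

The source may report more compounds than this note shows. Statements on the series, on what has been measured and on what is new or still open speak of the compounds shown alone.

Compound 1 `CC(C)(C)Cc1cnc(CCc2ccc(-c3ccccc3C(=O)O)cc2)[nH]1` was tested in an in vitro functional assay on cells for agonist activity at Bombesin receptor subtype-3 (Homo sapiens), read by luminescence and calcium flux (on this read-out lower numbers stand for an effect already at smaller amounts and higher numbers for an effect only at larger amounts of compound), where it gives 106 nM. Among the numbers reported, compound 1 stands lowest of the two; its nearest neighbour is compound 2 `CCCCc1cnc(C(C)Cc2ccc(-c3ccccc3C(=O)O)cc2)[nH]1`, which gives 2760 nM in this assay, a gap well beyond the usual scatter. Compound 3 `CCCCc1cnc(Cc2ccc(-c3ccccc3C(=O)O)cc2)[nH]1` reaches only a limit in this assay, > 10000 nM, so no number is known for it (the limit of > 10000 nM in this assay, at which 1 of the 3 values shown sits). No two of these three compounds differ in a single place, so no isolated step can be read from the measured values.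

Compound 4 `O=C(O)c1ccccc1-c1ccc(CCc2ncc(C3CCCCC3)[nH]2)cc1` has not yet been measured. It differs from compound 1 by cyclohexyl in place of neopentyl on an aromatic carbon. Both the group that leaves and the group that enters are built of carbon alone, carry neither hydrogen-bond donors nor acceptors, and bear no charge; the change is thus one of shape rather than of polarity.

Going by the values given here, with no measured step among compounds 1, 2 and 3 to lean on, one expects a 1.7-fold higher number from compound 1 to compound 4 (0.23 log units; within the scatter) to be small, either none beyond the scatter or a modest loss. Compound 4 is therefore estimated at 180 nM in this assay, with a range from 50 nM to 700 nM.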

Compound 4, half-maximal effective concentration: 375 nM
Compound 4: the middle estimate sits 2.1-fold (0.32 log units) below what was measured; the measured number falls inside the stated range.
By their numbers in this assay, from the lowest: compound 1; then compound 4; then compound 2. At a limit, above all of these: compound 3.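

Compound 4 gives the first step among these compounds that can be read in isolation: in this assay, cyclohexyl in place of neopentyl on an aromatic carbon of the five-membered aromatic ring gives a 3.5-fold higher number from compound 1 to compound 4 (0.55 log units; beyond the scatter). The step is modest but lies beyond the scatter, so this position distinguishes between two groups built of carbon alone, each with no hydrogen-bond donors, no hydrogen-bond acceptors and no net charge, and it accepts a six-membered ring of carbon only with a measured number still in hand. Nothing measured here gives a cause for this step.

Going by these compounds, what stays open is whether the step follows from the closing of the ring or from the shape of the group more broadly, a question that a cyclopentyl ring, a phenyl ring or an open hexyl chain at this place would bear on. On these data alone, it is also open how this position would respond to a group that is not carbon alone, such as an amine or a methoxy group, and whether the same exchange would give a similar step with the other linkers seen in compound 2 and compound 3.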